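The source may report more compounds than this note shows. Statements on the series, on what has been measured and on what is new or still open speak of the compounds shown alone.

Compound 1 `CC(Sc1nc2c(cnn2C)c(=O)n1-c1ccccc1)c1ccccn1`: 89 nM
Compound 2 `CC(Sc1nc2nn(C3COC3)cc2c(=O)n1-c1ccccc1)c1ccccc1`: 109 nM
Compound 3 `CC(Oc1nc2c(cnn2C)c(=O)n1-c1ccccc1)c1ccccc1`: 600 nM

All three were tested in an assay on isolated protein for inhibition of Retinaldehyde dehydrogenase 3 (Homo sapiens); a lower number here means a stronger inhibitor, a higher number a weaker inhibitor. Compound 1 and compound 2 sit within the usual scatter of each other, while compound 3 lies beyond it with a clearly higher number. Compound 4 `Cn1ncc2c(=O)n(-c3ccccc3)c(SC(C)(C)c3ccccc3)nc21` has not yet been measured. It differs from compound 1 in one place: 1-methyl-1-phenylethyl in place of 1-(pyridin-2-yl)ethyl on a sulfur. Among the compounds with values here, no measured pair isolates exactly this change, so the expectation rests on the values shown. Compound 2 gives 109 nM and stays close to compound 1 despite a different group on its sulfur, which suggests that the sulfur substituent tolerates variation. The step from compound 1 to compound 4 is therefore expected to be small, toward a slightly higher number, a 1.5-fold higher number from compound 1 to compound 4 (0.16 log units; within the scatter). For compound 4 the expected value is 130 nM, within a range from 40 nM to 420 nM.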

Compound 4, half-maximal inhibitory concentration: 1390 nM
The estimate for compound 4 lay 11-fold (1.03 log units) below the measured number; the whole stated range lies below it.
By their numbers in this assay, from the lowest: compounds 1 and 2 (each within the scatter of the next); then compound 3; then compound 4.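

In this assay, placing 1-methyl-1-phenylethyl on the sulfur instead of 1-(pyridin-2-yl)ethyl gives a 16-fold higher number from compound 1 to compound 4 (1.19 log units; beyond the scatter), so this position does not accept every group. The entering group differs in two ways: its ring is carbon only, and it has no hydrogen-bond acceptor, while its name also shows a second methyl. Nothing available explains the size of this step.

Which of these differences matters remains open. A 1-methyl-1-(pyridin-2-yl)ethyl group on the same sulfur would keep the ring nitrogen while carrying the second methyl, and so could help separate them.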